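Amino in place of trifluoromethoxy on compound 3

A few compounds are considered here, and "the series" means these few. Any claim that something is new, unique, unknown or untested is made for them only; others in the source may bear on it.

Measured values in an ADME assay on Raji cells (Homo sapiens) for cytotoxicity, with a stated time of 72 h (a higher number here means that more compound is needed for the effect, a lower number that less compound is needed), follow
- compound 1 (`CSc1ccc(NC(=O)Nc2cc(C)nc3ccccc23)cc1`) gives > 25000 nM as a limit
- compound 2 (`COC(=O)c1ccc(NC(=O)Nc2cc(C)nc3ccccc23)cc1`) gives 17000 nM
- compound 3 (`Cc1cc(NC(=O)Nc2ccc(OC(F)(F)F)cc2)c2ccccc2n1`) gives 10000 nM

On these numbers compound 3 cannot be separated from compound 2. Compound 4 (`Cc1cc(NC(=O)Nc2ccc(N)cc2)c2ccccc2n1`) carries amino in place of trifluoromethoxy on an aromatic carbon. Amino appears in no measured step. The swaps at this carbon gave one step within the scatter (a 1.7-fold lower number from compound 2 to compound 3 (0.23 log units; within the scatter)), one whose floor lies within it (an at least 1.4-fold lower number from compound 1 to compound 2 (0.16 log units; that floor lies within the scatter)) and one just beyond it that starts from a limit (an at least 2.5-fold lower number from compound 1 to compound 3 (0.39 log units; beyond the scatter)). On those sizes no step beyond the scatter is expected in this assay from this change, in either direction. The estimated step is small (a 1.4-fold higher number from compound 3 to compound 4 (0.15 log units; within the scatter)). Compound 4 is expected at 14000 nM (estimated range 5000 nM to 25000 nM).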

Compound 4, half-maximal effective concentration: > 25000 nM
Compound 4: only a limit was reported; the forecaster's own chance of this, stated with the estimate: 20%; middle value at least 1.7-fold (0.25 log units) away from the limit.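

In this assay, amino in place of trifluoromethoxy gives an at least 2.5-fold higher number from compound 3 to compound 4 (0.39 log units; beyond the scatter), so a change at this aromatic carbon now moves the number upward beyond the scatter. Amino in place of methoxycarbonyl gives an at least 1.4-fold higher number from compound 2 to compound 4 (0.16 log units; that floor lies within the scatter), and the step between compound 1 and compound 4 cannot be read. Compound 4 joins compound 1 at the assay's limit: the limit of > 25000 nM in this assay, at which 2 of the 4 values shown sit.

Going by these compounds, the full size of the amino step stays open, since compound 4 has only a limit. Also open, on these data alone, is whether a carboxylic acid or an acetamide at this carbon would read under that limit.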